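One group exchanged on compound 2

The compounds below may be only part of what the source reports. "The series", "measured", "known", "first", "only" and "open" are said of these compounds alone.

Values so far in an ADME assay on MT4 cells (Homo sapiens) for cytotoxicity, read by MTT assay (on this read-out higher numbers stand for lower toxicity in this test and lower numbers for higher toxicity in this test), are these
Compound 1 `Cc1ccc(N(C(=O)c2ccccc2C)C(=S)OCCN2C(=O)c3ccccc3C2=O)cc1` gives > 100000 nM (a limit of the assay, not a number)
Compound 2 `Cc1ccc(N(C(=O)c2c(F)cccc2F)C(=S)OCCN2C(=O)c3ccccc3C2=O)cc1` gives 65000 nM (the only actual number)

Compound 3 `Cc1ccc(N(C(=O)c2ccc(Cl)cc2Cl)C(=S)OCCN2C(=O)c3ccccc3C2=O)cc1` differs from compound 2 in one group (2,4-dichlorophenyl in place of 2,6-difluorophenyl on a carbonyl carbon). One measured step also exchanged a group on a carbonyl carbon (an at least 1.5-fold lower number from compound 1 to compound 2 (0.18 log units; that floor lies within the scatter)), and that size is only a floor, within the scatter. Compound 1 stands at a limit (the limit of > 100000 nM in this assay, at which 1 of the 2 values shown sits). On this slim evidence, no step beyond the scatter is expected in this assay. The expected step is small (a 1.2-fold lower number from compound 2 to compound 3 (0.07 log units; within the scatter)). Compound 3 is estimated at 55000 nM (expected range 22000 nM to 100000 nM).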

Compound 3, half-maximal cytotoxic concentration: 49000 nM
Estimate against measurement, compound 3: 1.1-fold (0.05 log units) above; the range from low to high includes it.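

In this assay this place on the carbonyl carbon now has two actual numbers to compare. Exchanging the two fluorines of 2,6-difluorophenyl for the two chlorines of 2,4-dichlorophenyl gives a 1.3-fold lower number from compound 2 to compound 3 (0.12 log units; within the scatter) and so no change beyond the scatter. The step of an at least 2.0-fold lower number from compound 1 to compound 3 (0.30 log units; that floor lies within the scatter) is only a floor, and compound 1 gives a limit rather than a number: the limit of > 100000 nM in this assay, at which 1 of the 3 values shown sits.

All three compounds carry a substituted phenyl at this place. As far as these compounds go, how an amine or a carboxylic acid on that ring would read in this assay remains open.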